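Swapping the Amine Arm for a Thioether on the Core

The compounds below may be only part of what the source reports. "The series", "measured", "known", "first", "only" and "open" are said of these compounds alone.

Of the compounds shown here, two have been measured in an assay on IMR-32 cells for displacement of a labelled ligand from corticotropin-releasing factor receptor 1 (Homo sapiens), read by scintillation counting, with a stated time of 2 h; a lower number here means a stronger inhibitor, a higher number a weaker inhibitor. Compound 1 `CCc1nc(N(CC2CC2)CC2CC2)c(CC)nc1-c1ccc(Cl)cc1Cl` gives 26 nM, the higher of the two numbers, while compound 2 `CCc1nc(-c2ccc(OC)nc2OC)c(CC)nc1NC(CC)CC` gives 11.6 nM, a gap beyond the scatter. Compound 3 `CCc1nc(-c2ccc(Cl)cc2Cl)c(CC)nc1SC(C)CC` has not yet been measured; it differs from compound 1 by (sec-butyl)sulfanyl in place of bis(cyclopropylmethyl)amino on an aromatic carbon. Within the data shown here, no measured pair shows this change, so the expected step rests on judgement alone. Compound 3 is expected to give a somewhat higher number, a step of a 2.3-fold higher number from compound 1 to compound 3 (0.36 log units; beyond the scatter) that may still fall within the scatter. The estimate for compound 3 is 60 nM, ranging from 15 nM to 300 nM.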

Compound 3, inhibition constant: 401 nM
Beside the measured number, compound 3's estimate is 6.7-fold (0.82 log units) below it; the measured number lies above the stated range.
By their numbers in this assay, from the lowest: compound 2; then compound 1; then compound 3.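

With the 2,4-dichlorophenyl group unchanged, (sec-butyl)sulfanyl in place of bis(cyclopropylmethyl)amino gives a 15-fold higher number from compound 1 to compound 3 (1.19 log units; beyond the scatter), a large step well beyond the scatter. The group on this aromatic carbon therefore strongly affects the measured inhibition, which compounds 1 and 2 could not show, as they differ in more than one place. Nothing available explains this loss. The compounds shown leave open whether the sulfur or the smaller, ring-free arm accounts for the step. A sec-butylamino group on the same aromatic carbon would separate these two changes.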